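Fluoro added to the azido compound: an open step

This account rests on a few compounds, and the source may have more. Where it says the series, first, only, none or still open, it means among the compounds named here.

Measured in a functional assay on SKW3 cells (Homo sapiens) for antiproliferative activity, read by WST assay, with a stated time of 3 days; a lower number here means a stronger inhibitor, a higher number a weaker inhibitor:
compound 1 `[N-]=[N+]=Nc1cc(=O)[nH]c(=O)n1[C@@H]1O[C@H](CO)[C@@H](O)[C@H]1O`: > 50000 nM
compound 2 `CNc1cc(=O)[nH]c(=O)n1[C@@H]1O[C@H](CO)[C@@H](O)[C@H]1O`: > 50000 nM
compound 3 `O=c1cc(NO)n([C@@H]2O[C@H](CO)[C@@H](O)[C@H]2O)c(=O)[nH]1`: > 50000 nM

Each of these three entries is a limit and not a number. Compound 1 therefore has no exact standing, as the limit of > 50000 nM in this assay, at which 3 of the 3 values shown sit, shows. Compound 4 `[N-]=[N+]=Nc1c(F)c(=O)[nH]c(=O)n1[C@@H]1O[C@H](CO)[C@@H](O)[C@H]1O` carries fluoro in place of hydrogen on an aromatic carbon, ortho to an azido group: fluoro in place of hydrogen on an aromatic carbon. Two measured steps change the azido group itself: a step that the two limits leave unreadable from compound 1 to compound 2 and a step that the two limits leave unreadable from compound 1 to compound 3. Going by the values given here, neither gives a size, and neither adds fluoro, so no measured step sets the size or direction of this one. In this assay, the expected change is a number no higher from compound 1 to compound 4 (the limit leaves the size open). For compound 4 the estimated value is 50000 nM, with an expected range of 10000 nM to 100000 nM.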

Compound 4, half-maximal inhibitory concentration: 400 nM
Beside the measured number, compound 4's estimate is 130-fold (2.10 log units) above it; measured number below the stated range.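

Fluoro in place of hydrogen on this aromatic carbon, ortho to an azido group, gives an at least 120-fold lower number from compound 1 to compound 4 (2.09 log units; beyond the scatter) in this assay. This place on the ring therefore responds strongly, and this one replacement is enough to take the azido compound off the limit. Compound 4 is the only compound shown with a number and not a limit: the limit of > 50000 nM in this assay, at which 3 of the 4 values shown sit.

Whether the step depends on the azido group stays open, as the methylamino and hydroxyamino compounds shown carry no fluoro. The compounds shown also leave open what chloro or methyl would do on this same carbon.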